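Amide variation in a shared-core series: cytotoxicity notes

The source may hold more compounds than are shown below. What is called first, only, known or untested is meant among the compounds shown, and "the series" means these compounds.

Measured so far:
compound 1, `CC(C)CC(=O)NCCCN1CCN(CCCNc2ccnc3cc(Cl)ccc23)CC1`, "not determined" (no result reported) in an ADME assay on L6 cells (Rattus norvegicus) for cytotoxicity; a higher number here means a weaker inhibitor, a lower number a stronger inhibitor
compound 2, `O=C(NCCCN1CCN(CCCNc2ccnc3cc(Cl)ccc23)CC1)c1cccc(OC(F)(F)F)c1`, 8500 nM in this assay
compound 3, `Cc1ccccc1C(=O)NCCCN1CCN(CCCNc2ccnc3cc(Cl)ccc23)CC1`, "not determined" (no result reported) in this assay

Compound 1 stands without a number in this assay; compound 3 likewise has none, so the only anchor in the set is compound 2, which gives 8500 nM in this assay. Within the data shown here, no step between two measured compounds can be drawn, and nothing connects compound 1 to compound 2 by a single change.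

Compound 4, `COc1cccc(C(=O)NCCCN2CCN(CCCNc3ccnc4cc(Cl)ccc34)CC2)c1`, is the next member. The difference from compound 1 is 3-methoxyphenyl in place of isobutyl on a carbonyl carbon. Compound 4 thereby carries an aryl group on its amide carbonyl, as compound 2 does, while compound 1 carries a branched chain there.

Among the measured compounds shown here, with no step available, the expectation rests on compound 2 alone. Since compound 2 gives 8500 nM in this assay and shares the amide-on-aryl arrangement, compound 4 is not expected to move beyond the scatter from it. Compound 4 is therefore estimated at 8000 nM in this assay, with a range from 3000 nM to 25000 nM, and it is expected that the assay may report only a limit for compound 4.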

Compound 4, half-maximal inhibitory concentration: 9300 nM
For compound 4 the middle estimate is 1.2-fold (0.07 log units) below the measured one; the measured number falls inside the stated range.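

In this assay, among these compounds, the series now has its only readable step: methyl in place of trifluoromethyl on an oxygen on an aromatic ring gives a 1.1-fold higher number from compound 2 to compound 4 (0.04 log units; within the scatter) and so leaves compound 2 and compound 4 within the scatter of each other, something that compound 2 alone could not show. This reading covers that one exchange on the oxygen; compound 1 and compound 3 carry no number, so steps to them, including the change from isobutyl to 3-methoxyphenyl on a carbonyl carbon, cannot be read. No measured evidence bears on why the two values lie so close.

The compounds shown leave open whether an oxygen-free group on the aromatic ring, such as a carboxylic acid or a dimethylamino group, would hold the reading within the scatter of these two values. They also leave open whether a longer chain on that oxygen, such as n-butyl in place of methyl, would do so, and how an aryl group compares with a branched chain on the amide carbonyl in this cytotoxicity read-out.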